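The source may report more compounds than this note shows. Statements on the series, on what has been measured and on what is new or still open speak of the compounds shown alone.

Working notes on the series in an ADME assay on SNB-19 cells (Homo sapiens) for cytotoxicity, read by MTT assay, with a stated time of 24 h; a lower number here means that less compound is tolerated, a higher number that more compound is tolerated. Among the compounds with values here, compound 3 `C=C1CC[C@H]2[C@@](C)(CCC(=O)[C@@]2(C)COC(C)=O)[C@@H]1C/C=C1/C(=O)OC[C@@H]1Oc1cccc2ccc(C)nc12` gives 51700 nM in this assay, the higher of the two numbers measured so far; compound 2 `C=C1CC[C@@H]2[C@](C)(CO)[C@H](O)CC[C@@]2(C)[C@@H]1C/C=C1/C(=O)OC[C@@H]1Oc1cccc2cccnc12` gives 22700 nM, and that gap lies beyond the usual scatter. Compound 1 `C=C1CC[C@H]2[C@@](C)(CCC(=O)[C@@]2(C)COC(C)=O)[C@@H]1C/C=C1/C(=O)OC[C@H]1Oc1c(Cl)cc(Cl)c2cccnc12` is reported only as a limit in this assay, > 100000 nM. That reading is the limit of > 100000 nM in this assay, at which 1 of the 3 values shown sits. Compound 4 `C=C1CC[C@H]2[C@@](C)(CCC(=O)[C@@]2(C)COC(C)=O)[C@@H]1C/C=C1/C(=O)OC[C@@H]1Oc1c(Cl)cc(Cl)c2cccnc12` has not yet been measured. It differs from compound 3 in one place, by 5,7-dichloroquinolin-8-yl in place of 2-methylquinolin-8-yl on an oxygen on a saturated carbon. Within the data shown here, no measured pair in this set makes exactly this change, so the size of the step cannot be read directly from a neighbour. Compound 1 also carries 5,7-dichloroquinolin-8-yl on an oxygen on a saturated carbon, and compound 1 returns only the limit > 100000 nM. On that basis a step upward beyond the scatter is expected from compound 3 to compound 4, with a real chance that this assay again reports only a limit rather than a number. The expected value for compound 4 is 90000 nM, with a range from 40000 nM to 200000 nM. The step this estimate implies is a 1.7-fold higher number from compound 3 to compound 4 (0.24 log units; within the scatter).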

Compound 4, half-maximal cytotoxic concentration: 72000 nM
Estimate against measurement, compound 4: 1.3-fold (0.10 log units) above; the measured number falls inside the stated range.
By their numbers in this assay, from the lowest: compound 2; then compounds 3 and 4 (each within the scatter of the next). At a limit, above all of these: compound 1.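

In this assay, within the data shown here, the first direct reading of this change on the shared core is a 1.4-fold higher number from compound 3 to compound 4 (0.14 log units; within the scatter), so at this place 5,7-dichloroquinolin-8-yl and 2-methylquinolin-8-yl cannot be told apart, and compounds 3 and 4 sit together within the scatter. The 5,7-dichloroquinolin-8-yl group also now has a real number, compound 4 at 72000 nM. Carrying this group does not by itself put a compound at the limit of the assay. The second reading, an at least 1.3-fold lower number from compound 1 to compound 4 (0.14 log units; that floor lies within the scatter), rests on a limit, so it shows no difference beyond the scatter and gives only a floor for the change in drawn configuration at the saturated ring carbon, in a pair that isolates that one change: the fact that compounds 1 and 4 differ only in the configuration as drawn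

From the compounds shown here alone, the true size of that configuration step stays open, since compound 1 is a limit reading, and so does whether the step from compound 3 to compound 4 carries over to the core of compound 2. Also open, going by these compounds, is how the number would move with an amine or a carboxylic acid in place of these quinolin-8-yl groups on the same oxygen.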